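The source may hold more compounds than are shown below. What is called first, only, known or untested is meant among the compounds shown, and "the series" means these compounds.

Measured in a functional assay on THP-1 cells (Homo sapiens) for inhibition; a higher number here means a weaker inhibitor of growth, a lower number a stronger inhibitor of growth:
Compound 1 `Cc1noc(C)c1-c1ccc2c(c1)c(Cc1ccccc1)cn2CCCCCC(=O)NO`: 15500 nM
Compound 2 `Cc1noc(C)c1-c1ccc2c(c1)c(CCc1ccc(F)cc1)cn2CCCCCCC(=O)NO`: 15500 nM
Compound 3 `Cc1ccccc1Cc1cn(CCCCCCC(=O)NO)c2ccc(-c3c(C)noc3C)cc12`: 15500 nM

Compound 1 stands level with compound 2 and compound 3, and all three give the same number. Compound 4 `Cc1cccc(Cc2cn(CCCCCC(=O)NO)c3ccc(-c4c(C)noc4C)cc23)c1` keeps the core of compound 1 and carries methyl in place of hydrogen on an aromatic carbon, meta to a large group: methyl in place of hydrogen on an aromatic carbon. Going by the values given here, the one measured step between compounds differing in one place is no change at the digits printed from compound 2 to compound 3 (within the scatter). It exchanges a different group, so it bears on this change only loosely, and it stays within the scatter. No step beyond the scatter is therefore expected in this assay. The expected step is no change at the digits printed from compound 1 to compound 4 (within the scatter). Compound 4 is estimated at 15500 nM, with an expected range of 7000 nM to 25000 nM.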

Compound 4, concentration for 50% growth inhibition: 15500 nM
Compound 4: middle estimate and measured number agree at the digits printed; the range from low to high includes it.
By their numbers in this assay, from the lowest: compounds 1, 2, 3 and 4 (each within the scatter of the next).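

Going from benzyl to 3-methylbenzyl gives no change at the digits printed from compound 1 to compound 4 (within the scatter) in this assay and is the first step shown that reads this ring position directly. At this place, on an aromatic carbon and meta to a large group, adding a single methyl leaves the growth-inhibition number within the scatter. Nothing measured here explains this result.

The compounds shown leave open whether an amine, a carboxylic acid or a methoxy group at this same carbon would shift the number. They also leave open whether a methyl on another carbon of this ring would do so.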